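A Methyl on the Pyrimidine of Compound 3

This account rests on a few compounds, and the source may have more. Where it says the series, first, only, none or still open, it means among the compounds named here.

Three compounds have been measured in a functional assay on LNCaP cells (Homo sapiens) for antiproliferative activity, read by CCK-8 assay, with a stated time of 6 days; on this read-out higher numbers stand for weaker inhibition and lower numbers for stronger inhibition:

Compound 1 `C[C@@H](Cn1ccc(-c2ccc(C#N)c(Cl)c2)n1)Nc1cccnc1` gives 430 nM
Compound 2 `C[C@@H](Cn1ccc(-c2ccc(C#N)c(Cl)c2)n1)Nc1ccncc1` gives 2560 nM
Compound 3 `C[C@@H](Cn1ccc(-c2ccc(C#N)c(Cl)c2)n1)Nc1ncccn1` gives 1180 nM

Compound 3 stands second highest of the three numbers: it sits below compound 2, as a 2.2-fold lower number from compound 2 to compound 3 (0.34 log units; beyond the scatter) shows, and above compound 1, as a 2.7-fold higher number from compound 1 to compound 3 (0.44 log units; beyond the scatter) shows. Compound 4 `Cc1ccnc(N[C@@H](C)Cn2ccc(-c3ccc(C#N)c(Cl)c3)n2)n1` differs from compound 3 by methyl in place of hydrogen on an aromatic carbon. Going by the values given here, none of the measured steps bears directly on this change: a 6.0-fold higher number from compound 1 to compound 2 (0.77 log units; beyond the scatter), a 2.7-fold higher number from compound 1 to compound 3 (0.44 log units; beyond the scatter) and a 2.2-fold lower number from compound 2 to compound 3 (0.34 log units; beyond the scatter) each exchange one amine-borne ring for another, and none adds a methyl to a ring that is kept. For compound 4 in this assay a step within the scatter is therefore expected, a 1.2-fold lower number from compound 3 to compound 4 (0.07 log units; within the scatter), with an estimate of 1000 nM lying between 350 nM and 3000 nM.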

Compound 4, half-maximal inhibitory concentration: 1330 nM
Estimate against measurement, compound 4: 1.3-fold (0.12 log units) below; low and high end bracket the measured number.
By their numbers in this assay, from the lowest: compound 1; then compounds 3, 4 and 2 (each within the scatter of the next, the first and the last beyond it).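

In this assay, methyl on this aromatic carbon, next to the ring nitrogen, leaves the number within the scatter (a 1.1-fold higher number from compound 3 to compound 4 (0.05 log units; within the scatter)). The 4-methylpyrimidin-2-yl ring of compound 4 also stays within the scatter of the pyridin-4-yl ring (a 1.9-fold lower number from compound 2 to compound 4 (0.28 log units; within the scatter)), but the pyridin-3-yl ring remains apart (a 3.1-fold higher number from compound 1 to compound 4 (0.49 log units; beyond the scatter)). Nothing measured here offers an explanation for these steps. On these data alone, whether an ethyl, a methoxy or an amine on this carbon would also leave the number within the scatter remains open, as does the effect of a methyl on the pyridin-3-yl ring of compound 1.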